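A few compounds are considered here, and "the series" means these few. Any claim that something is new, unique, unknown or untested is made for them only; others in the source may bear on it.

Compound 1 `CCCCCCCCCCCCn1nnc(C(C(=O)Nc2ccc3c(C)cc(C)nc3n2)c2ccccc2)n1` gives 1540 nM in an assay on liver for inhibition of sterol O-acyltransferase 1 (Rattus norvegicus), using microsomes; a lower number here means a stronger inhibitor, a higher number a weaker inhibitor.
Compound 2 `CCCCCCCCCCCCn1nnc(C(C(=O)NC2CC2)c2ccccc2)n1` gives 244 nM in this assay.
Compound 3 `CCCCCCCCCCCCn1nnc(C(F)C(=O)Nc2c(OC)cc(OC)cc2OC)n1` gives 1760 nM in this assay.

Among these three numbers compound 3 sits at the top, but its gap to compound 1 lies within the usual scatter, so those two cannot be told apart; only compound 2 stands clearly lower. Among the compounds with values here, the one measured step, a 6.3-fold lower number from compound 1 to compound 2 (0.80 log units; beyond the scatter), concerns a change on the amide nitrogen and leaves the rest of the molecule untouched. Compound 4 `CCCCCCCCCCCCn1nnc(CC(=O)Nc2c(OC)cc(OC)cc2OC)n1` differs from compound 3 in another place: hydrogen in place of fluoro on a saturated chain carbon bound to an aromatic carbon and a carbonyl carbon. Within the data shown here, no measured pair differs in that way, so no measured step bears directly on this change, and the step on the amide nitrogen gives no guidance about it. The expected step is therefore a 1.2-fold lower number from compound 3 to compound 4 (0.07 log units; within the scatter), none beyond the scatter. Compound 4 is expected to give about 1500 nM in this assay, with a range from 500 nM to 4500 nM.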

Compound 4, half-maximal inhibitory concentration: 24 nM
The estimate for compound 4 lay 63-fold (1.80 log units) above the measured number; measured number below the stated range.
By their numbers in this assay, from the lowest: compound 4; then compound 2; then compounds 1 and 3 (each within the scatter of the next).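

The change of a single atom on the saturated chain carbon bound to an aromatic carbon and a carbonyl carbon has a large effect in this assay: hydrogen in place of fluoro gives a 73-fold lower number from compound 3 to compound 4 (1.87 log units; beyond the scatter). Within the data shown here, the only step available before this one lay on the amide nitrogen, so the earlier compounds gave no sign that this carbon could matter so much. Nothing at hand accounts for the size of this step.

From the compounds shown here alone, how a methyl group, a chlorine atom or a hydroxyl group on this carbon would compare with hydrogen and fluoro remains open. Compounds 1 and 2 carry a phenyl ring on this carbon but also differ from compound 4 on the amide nitrogen, so they cannot show what the phenyl ring alone does.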